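The compounds below may be only part of what the source reports. "The series", "measured", "known", "first", "only" and "open" are said of these compounds alone.

Measured so far:
compound 1 `CCCS(=O)(=O)Nc1ccc(F)c(C(=O)c2n[nH]c3ncc(-c4ccc(N)cc4)cc23)c1F`: 0.1%
compound 2 `CCCS(=O)(=O)Nc1ccc(F)c(C(=O)c2n[nH]c3ncc(-c4cccc(N(C)C)c4)cc23)c1F`: 26%
compound 3 `CCCS(=O)(=O)Nc1ccc(F)c(C(=O)c2n[nH]c3ncc(-c4ccc(Cl)c(Cl)c4)cc23)c1F`: 45%

In an assay for binding affinity to dual specificity mitogen-activated protein kinase kinase 4 (Homo sapiens), read by KINOMEscan, tested at 100 nM (on this read-out lower numbers stand for a stronger effect and higher numbers for a weaker effect at the one concentration tested), compound 2 gives 26%, the second highest of the three numbers; the nearest step is a number 19 percentage points higher from compound 2 to compound 3 (beyond the scatter), the furthest a number 25.9 percentage points higher from compound 1 to compound 2 (beyond the scatter). Compound 4 `CCCS(=O)(=O)Nc1ccc(F)c(C(=O)c2n[nH]c3ncc(-c4ccc(C(=O)O)cc4)cc23)c1F` has not yet been measured. It differs from compound 2 in one place: 4-carboxyphenyl in place of 3-(dimethylamino)phenyl on an aromatic carbon. For the measured compounds named here, the steps that bear on it exchange the same aryl group: a number 25.9 percentage points higher from compound 1 to compound 2 (beyond the scatter) was modest and a number 44.9 percentage points higher from compound 1 to compound 3 (beyond the scatter) was large. Going by the values given here, no measured step brings in a carboxy group, so the direction of this change is open. Compound 4 is therefore expected to show a number 4 percentage points higher from compound 2 to compound 4 (within the scatter), not clearly beyond the scatter. The value of compound 4 is estimated at 30%, ranging from 5% to 80%.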

Compound 4, a percentage reported as activity, at one concentration (the size of the read-out at that concentration, not a potency): 0.1%
Compound 4: middle estimate off by 29.9 percentage points, on the high side; measured number below the stated range.
By their numbers in this assay, from the lowest: compounds 1 and 4 (each within the scatter of the next); then compound 2; then compound 3.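

In this assay, 4-carboxyphenyl brings a number 25.9 percentage points lower from compound 2 to compound 4 (beyond the scatter) and a number 44.9 percentage points lower from compound 3 to compound 4 (beyond the scatter), so this aromatic carbon accepts a carboxy group without any loss against the other two aryl groups. Carboxy in place of amino gives no change at the digits printed from compound 1 to compound 4 (within the scatter), which shows that the amino group is not needed for a number this low. A single group at the 4-position of the phenyl ring is shared by these two compounds, while 3,4-dichlorophenyl in compound 3 also carries a group there and still gives the highest number.

No measurement shown explains these differences. Going by these compounds, whether plain phenyl, 4-hydroxyphenyl or 4-methylphenyl would also give so low a number remains open.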